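Swapping a Thiophene for a Fluoropyridine on a Shared Core

The source may report more compounds than this note shows. Statements on the series, on what has been measured and on what is new or still open speak of the compounds shown alone.

Measured so far:
compound 1, `COc1ccc(CN2C(=O)C(=O)c3cc(OC(F)(F)F)ccc32)cc1`, 1100 nM
compound 2, `O=C1C(=O)N(Cc2ccc(-c3ccsc3)cc2)c2ccc(OC(F)(F)F)cc21`, 2800 nM

In a functional assay on CHO cells for agonist activity at muscarinic acetylcholine receptor M5 (Homo sapiens), read by calcium flux (on this read-out higher numbers stand for an effect only at larger amounts of compound and lower numbers for an effect already at smaller amounts), compound 2 gives the highest of the two numbers; its nearest neighbour is compound 1, which sits lower by a 2.5-fold higher number from compound 1 to compound 2 (0.41 log units; beyond the scatter). Compound 3, `O=C1C(=O)N(Cc2ccc(-c3ccc(F)nc3)cc2)c2ccc(OC(F)(F)F)cc21`, changes compound 2 in one place: 6-fluoropyridin-3-yl in place of thiophen-3-yl on an aromatic carbon. Among the compounds with values here, only the step from compound 1 to compound 2 is known, and it concerns a different group at the same position, so it gives little direct guidance. One aromatic ring replaces another of similar kind, so no step beyond the scatter is expected. Compound 3 is therefore estimated at 2500 nM, within 900 nM to 7000 nM, a step of a 1.1-fold lower number from compound 2 to compound 3 (0.05 log units; within the scatter).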

Compound 3, half-maximal effective concentration: 3600 nM
Compound 3: the middle estimate sits 1.4-fold (0.16 log units) below what was measured; measured number inside the range.
By their numbers in this assay, from the lowest: compound 1; then compounds 2 and 3 (each within the scatter of the next).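

In this assay, exchanging one aromatic ring for another at this position gives a 1.3-fold higher number from compound 2 to compound 3 (0.11 log units; within the scatter), so thiophen-3-yl and 6-fluoropyridin-3-yl cannot be told apart here, despite their different ring sizes. Set against methoxy, 6-fluoropyridin-3-yl gives a 3.3-fold higher number from compound 1 to compound 3 (0.51 log units; beyond the scatter), so the two aromatic rings now stand on the same side of compound 1. No measurement at hand accounts for this result.

Still open, as far as these compounds go, is how a plain phenyl ring, an amine or a carboxylic acid would read at this position. Also open, from the compounds shown here alone, is whether these steps would hold with another group in place of trifluoromethoxy on the shared core.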